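A few compounds are considered here, and "the series" means these few. Any claim that something is new, unique, unknown or untested is made for them only; others in the source may bear on it.

Among the measured compounds shown here, compound 1 `COc1ccc(-c2cc3[nH]nc(N)c3c(=O)[nH]2)cc1` is one of three compounds measured in an assay on isolated protein for inhibition of RAC-beta serine/threonine-protein kinase (Homo sapiens), read by mobility shift assay, tested at 30 uM (a higher number here means more inhibition at the concentration tested (going by the name of the read-out), a lower number less inhibition), where compound 1 gives 11%. Compound 2 `CN1CCN(c2ccc(-c3cc4[nH]nc(N)c4c(=O)[nH]3)cc2)CC1` gives 6%, and compound 3 `Cn1nc(N)c2c(=O)[nH]c(-c3ccccn3)cc21` gives 10%. For the measured compounds named here, all three numbers lie within the usual scatter of one another, so none of the compounds can be set apart from the rest: the only single-place step, a number 5 percentage points lower from compound 1 to compound 2 (within the scatter), shows how little an exchange on the aromatic ring moves the read-out here.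

Compound 4 `COc1ccc(-c2cc3c(c(N)nn3C)c(=O)[nH]2)cc1` differs from compound 1 by methyl in place of hydrogen on an aromatic nitrogen. Going by the values given here, no measured step changes this position alone. Compound 3 carries the same methyl on that ring nitrogen but also a different aromatic group, so the two compounds together give only a hint. Compound 1 gives 11%, and compound 3 gives 10%, which is no difference beyond the scatter. The expectation for compound 4 in this assay is therefore a step of a number 1 percentage points lower from compound 1 to compound 4 (within the scatter), nothing beyond the scatter. The estimated value for compound 4 is 10%, within a range of 0% to 25%.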

Compound 4, a percentage reported as inhibition, at one concentration (the size of the read-out at that concentration, not a potency): -8%
Compound 4: the middle estimate sits 18 percentage points above what was measured; measured number below the stated range.
By their numbers in this assay, from the lowest: compound 4; then compounds 2, 3 and 1 (each within the scatter of the next).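

Placing a methyl on the aromatic nitrogen of the five-membered ring gives a number 19 percentage points lower from compound 1 to compound 4 (beyond the scatter) in this assay, the only step here that lies beyond the scatter. Among the compounds shown here, this nitrogen is therefore a position where a single added carbon registers in the read-out, unlike the one exchange seen before, which stayed within the scatter. The size of this step is modest, and nothing shown here explains why the number falls.

Going by these compounds, it remains open whether a longer chain on the same nitrogen, such as ethyl or 2-hydroxyethyl, would give a similar number to methyl or a different one. The compounds also leave open whether the same methyl would produce a comparable step in a compound carrying 4-methylpiperazin-1-yl in place of methoxy.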